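The source may hold more compounds than are shown below. What is called first, only, known or untested is meant among the compounds shown, and "the series" means these compounds.

Measured compounds:
compound 1, `CCCCNc1nc(N)nc2c1CCN(Cc1ccccc1)C2`, 0.4 uM
compound 2, `CCCCNc1nc(N)nc2c1CN(C(C)=O)CC2`, 0.5 uM
compound 3, `CCCCNc1nc(N)nc2c1CN(Cc1cccc(Cl)c1Cl)CC2`, 0.18 uM

The three measured compounds share one core and differ only in the group carried by the ring nitrogen. In an assay on HEK293 cells for agonist activity at Toll-like receptor 8 (Homo sapiens), read by a luciferase reporter, with a stated time of 6 h (on this read-out lower numbers stand for an effect already at smaller amounts and higher numbers for an effect only at larger amounts of compound), compound 2 gives 0.5 uM, the highest of the three numbers. Compound 1 stands closest to it with 0.4 uM, and the two values lie within the scatter of each other, so no order can be read between them. Compound 3, with 0.18 uM, stands furthest from compound 2, and that gap lies beyond the scatter.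

Compound 4, `CCCCNc1nc(N)nc2c1CN(C(=O)c1cnccn1)CC2`, has not yet been measured. It differs from compound 2 in one place: pyrazin-2-yl in place of methyl on a carbonyl carbon. Among the compounds with values here, no measured pair shows this kind of exchange, so the size of the step can only be guessed from the spread of the three numbers.

The expectation for compound 4 is a small step toward a lower number, not beyond the scatter: the estimated step is a 1.7-fold lower number from compound 2 to compound 4 (0.22 log units; within the scatter). Compound 4 is therefore expected to give about 0.3 uM, with a range from 0.1 uM to 1 uM.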

Compound 4, minimum effective concentration: 2.2 uM
Compound 4: the middle estimate sits 7.3-fold (0.87 log units) below what was measured, outside the stated range (above it).
By their numbers in this assay, from the lowest: compound 3; then compounds 1 and 2 (each within the scatter of the next); then compound 4.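

In this assay, pyrazin-2-yl in place of methyl on a carbonyl carbon brings a 4.4-fold higher number from compound 2 to compound 4 (0.64 log units; beyond the scatter) and so gives the first step among these compounds that can be read for a single change. With the amide-type nitrogen in the ring kept, the group on the carbonyl carbon alone is enough to move the number beyond the scatter, and the move is upward, so this place on the shared core does not take every group alike. Nothing measured here gives a reason for this step.

How a phenyl group on the same carbonyl carbon, with only carbon atoms in its ring, would compare with pyrazin-2-yl stays open, so the compounds shown cannot separate the ring itself from its two nitrogen atoms. On these data alone, it is equally open whether a longer chain such as propyl in place of methyl would move the number at all, or whether an amine on that carbonyl carbon would take it up or down.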